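The source may hold more compounds than are shown below. What is called first, only, known or untested is meant among the compounds shown, and "the series" means these compounds.

Of the compounds shown here, two have so far been measured in a functional assay on ACHN cells (Homo sapiens) for cytotoxicity, read by sulforhodamine B assay, with a stated time of 48 h; on this read-out higher numbers stand for lower toxicity in this test and lower numbers for higher toxicity in this test. Compound 1 `ClCc1ccc(Cn2cnc3c(Cl)ncnc32)cc1` gives 3800 nM in this assay. Compound 2 `ClCc1ccccc1Cn1cnc2ncnc(Cl)c21` gives 9120 nM in this assay. Of these two numbers, compound 1 holds the lower one, and the number of compound 2 stands above it by a gap that exceeds the scatter of the method. For the measured compounds named here, the two structures differ in more than one place, so no single step is drawn between them.

Compound 3 `ClCc1ccc(Cn2cnc3c(Cl)nc(Cl)nc32)cc1` has not yet been measured in this assay. It differs from compound 1 by chloro in place of hydrogen on an aromatic carbon. Going by the values given here, no measured pair in this set shows such a change, so nothing here tells how large the step ought to be or which way it should run. The account therefore expects only a modest step in this assay, a 1.3-fold lower number from compound 1 to compound 3 (0.10 log units; within the scatter), one that should not reach beyond the usual scatter, with no direction favoured. On that basis compound 3 is estimated at 3000 nM in this assay, with a range from 1200 nM to 8000 nM.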

Compound 3, concentration lethal to 50% of the cells: 14800 nM
Estimate against measurement, compound 3: 4.9-fold (0.69 log units) below; the measured number lies above the stated range.
By their numbers in this assay, from the lowest: compound 1; then compounds 2 and 3 (each within the scatter of the next).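

For the compounds shown here, the step at this position is the first in the set that can be read, and it shows that in this assay the aromatic carbon between two ring nitrogen atoms is not a silent place on the core of compound 1. Chloro in place of hydrogen there gives a 3.9-fold higher number from compound 1 to compound 3 (0.59 log units; beyond the scatter), so on this read-out the added chlorine goes with lower toxicity in this test, and a change of a single heavy atom is enough to carry the number beyond the scatter. Nothing measured alongside these numbers accounts for the direction or the size of this step.

The compounds shown leave open whether this step belongs to chloro itself or whether another group on the same carbon, such as an amine, a methoxy group or a methyl group, would move the number in this assay the same way. Going by these compounds alone, with only this one pair showing the change, it also remains open whether chloro in place of hydrogen at this position would shift the number of compound 2 as it does that of compound 1.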